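Swapping the cyclohexyl substituent on a kinase inhibitor scaffold

The compounds below may be only part of what the source reports. "The series", "measured", "known", "first", "only" and "open" are said of these compounds alone.

Compound 2 `CNC(=O)[C@H]1CC[C@@H](Nc2cc(NCc3cnccc3C(F)(F)F)ncc2C#N)CC1` holds the lowest number of the two measured here: in an assay on isolated protein for inhibition of protein kinase C delta type (Homo sapiens), read by TR-FRET, with a stated time of 2 h (on this read-out higher numbers stand for weaker inhibition and lower numbers for stronger inhibition), compound 2 gives 1600 nM, while compound 1 `N#Cc1cnc(NCc2cnccc2C(F)(F)F)cc1N[C@H]1CC[C@H](O)CC1` gives 6500 nM. For the measured compounds named here, the one step measured, a 4.1-fold lower number from compound 1 to compound 2 (0.61 log units; beyond the scatter), bears directly on the change to compound 3 `CC1(C)C[C@H](Nc2cc(NCc3cnccc3C(F)(F)F)ncc2C#N)CC[C@H]1O`, which is 4-hydroxy-3,3-dimethylcyclohexyl in place of 4-(methylcarbamoyl)cyclohexyl on a nitrogen on an aromatic ring. That change undoes the carbamoyl-for-hydroxy swap while adding two methyl groups, so compound 3 is expected to move back toward compound 1, with a 3.1-fold higher number from compound 2 to compound 3 (0.49 log units; beyond the scatter) estimated. Compound 3 is therefore expected near 5000 nM, within a range from 1500 nM to 16000 nM.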

Compound 3, half-maximal inhibitory concentration: 2200 nM
Beside the measured number, compound 3's estimate is 2.3-fold (0.36 log units) above it; the measured number falls inside the stated range.
By their numbers in this assay, from the lowest: compounds 2 and 3 (each within the scatter of the next); then compound 1.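

For the compounds shown here, with the hydroxy group kept, 4-hydroxy-3,3-dimethylcyclohexyl in place of 4-hydroxycyclohexyl gives a 3.0-fold lower number from compound 1 to compound 3 (0.47 log units; beyond the scatter) in this assay, so the methylcarbamoyl group is not the only change at this position on the nitrogen that shifts the number. The other step, a 1.4-fold higher number from compound 2 to compound 3 (0.14 log units; within the scatter), leaves these two quite different cyclohexyl substituents indistinguishable. No evidence accounts for either step.

Open, as far as these compounds go, is whether the two methyl groups would have any such effect on 4-(methylcarbamoyl)cyclohexyl. Also open, from the compounds shown here alone, is how an amine or a carboxylic acid on the cyclohexyl ring would compare.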